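The compounds below may be only part of what the source reports. "The series", "measured", "known", "first", "only" and "open" are said of these compounds alone.

In a functional assay on LoVo cells (Homo sapiens) for cytotoxicity, read by MTT assay, with a stated time of 72 h (on this read-out lower numbers stand for stronger inhibition and higher numbers for weaker inhibition), compound 1 (`O=C1NC(=O)c2c1c1c3cc(O)ccc3[nH]c1c1cccn21`) gives 99000 nM, while compound 2 (`COc1ccc2[nH]c3c(c4c(c5ccnn53)C(=O)NC4=O)c2c1`) gives 34000 nM. Compound 2 therefore holds the lower of the two numbers, and its gap to compound 1 lies beyond the usual scatter of repeated measurements. These two compounds differ in more than one place, so their gap cannot be pinned on any single structural change.

The next compound, compound 3 (`Cc1ccc2[nH]c3c(c4c(c5ccnn53)C(=O)NC4=O)c2c1`), keeps the core of compound 2 but has methyl in place of methoxy on an aromatic carbon. Going by the values given here, no measured pair here differs in just one place, so the data offer no direct guide to the size of this change. The natural starting point is compound 2 at 34000 nM, with little expected to shift. The expected step, a 1.2-fold higher number from compound 2 to compound 3 (0.07 log units; within the scatter), is a slight rise in the number that stays within the scatter, and its direction is only a weak guess. For compound 3 the estimated value is 40000 nM, with an expected range from 14000 nM to 100000 nM.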

Compound 3, half-maximal inhibitory concentration: 4000 nM
Compound 3: middle estimate off by 10-fold (1.00 log units), on the high side, and the stated range ends above it.
By their numbers in this assay, from the lowest: compound 3; then compound 2; then compound 1.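

In this assay putting methyl in place of methoxy on this aromatic carbon gives an 8.5-fold lower number from compound 2 to compound 3 (0.93 log units; beyond the scatter) and so shows that this spot on the shared core, meta to a fused ring and para to a fused ring, is not a silent one: a change of a single small group moves the number beyond the scatter. Going by these compounds alone, this is the first pair here that differs in one place, so it gives the first size that can be tied to one change, which the gap between compound 1 and compound 2 could not do. The swap removes one oxygen and one hydrogen-bond acceptor, but nothing available here tells whether either of these accounts for the drop, and no measurement bears on its cause.

On these data alone, it remains open whether a chlorine atom, an ethyl group or an amine on the same aromatic carbon would land nearer compound 2 or compound 3. One pair also cannot tell whether the same swap would have a similar effect on a different core, such as that of compound 1.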